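The source may hold more compounds than are shown below. What is called first, only, known or untested is meant among the compounds shown, and "the series" means these compounds.

Measured so far, in an assay for inhibition of Nitric oxide synthase, inducible (Homo sapiens), with a stated time of 30 min, tested at 1 mM; a higher number here means more inhibition at the concentration tested (going by the name of the read-out), a lower number less inhibition:
compound 1 `COc1ccc(N)c(C(O)CCNC(C)=N)c1` gives 57.4%;
compound 2 `COc1ccc(N)c(C(O)CCNC(=N)c2ccccc2)c1` gives 95.9%.

Compound 2 stands highest of the two numbers; its nearest neighbour is compound 1, and the step of a number 38.5 percentage points higher from compound 1 to compound 2 (beyond the scatter) lies beyond the scatter. Compound 3 `COc1ccc(N)c(C(O)CCNC(=N)c2ccc(Cl)cc2)c1` differs from compound 2 in one place: chloro in place of hydrogen on an aromatic carbon. For the measured compounds named here, no measured step exchanges a ring hydrogen for chloro, so the single known step, phenyl for methyl, offers no direct guide. With the number for compound 2 already high, compound 3 is expected to stay near it, the step of a number 2.9 percentage points lower from compound 2 to compound 3 (within the scatter) falling within the scatter. The estimate for compound 3 is 93%, with a range from 80% to 100%.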

Compound 3, a percentage reported as inhibition, at one concentration (the size of the read-out at that concentration, not a potency): 81%
Compound 3: middle estimate off by 12 percentage points, on the high side, and the stated range covers the measured number.
By their numbers in this assay, from the lowest: compound 1; then compound 3; then compound 2.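

The ring of compound 2 turns out not to be indifferent to a change at this position: in this assay, chloro in place of hydrogen, para to a large group, gives a number 14.9 percentage points lower from compound 2 to compound 3 (beyond the scatter). Even so, the 4-chlorophenyl group keeps part of the gain over methyl, with a number 23.6 percentage points higher from compound 1 to compound 3 (beyond the scatter). Nothing measured here explains the drop.

From the compounds shown here alone, whether fluoro, methoxy or an amine in the same place would also lower the number stays open. So does whether a longer chain in place of methyl would approach phenyl.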